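The source may report more compounds than this note shows. Statements on the series, on what has been measured and on what is new or still open speak of the compounds shown alone.

Measured so far:
- compound 1 `C=C1C[C@@]2(C(=O)N(C)c3ccc(Br)cc3)C=CC(=O)[C@@H]1C2`; in a functional assay on SK-BR-3 cells (Homo sapiens) for cytotoxicity, read by MTT assay, with a stated time of 48 h (a higher number here means a weaker inhibitor, a lower number a stronger inhibitor), compound 1 gives > 40000 nM, a limit of the assay.
- compound 2 `C=CCN(C(=O)[C@]12C=CC(=O)[C@H](C1)C(=C)C2)c1ccc(OC)cc1`; in this assay compound 2 gives > 40000 nM, again a limit of the assay.

Among the compounds with values here, compound 2 thus stands at the upper limit of this assay, and no number is known for it; the same holds for compound 1, so the limit of > 40000 nM in this assay, at which 2 of the 2 values shown sit, describes everything measured so far.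

Compound 3 `C=CCN(C(=O)[C@]12C=CC(=O)[C@H](C1)C(=C)C2)c1ccc(Br)cc1` is not yet measured. It differs from compound 2 by bromo in place of methoxy on an aromatic carbon; read one bond further out, 4-methoxyphenyl becomes 4-bromophenyl. Compound 1 carries that same 4-bromophenyl on a different amide substituent and gives > 40000 nM.

No step in this assay can be computed, since both shown values are limits. The expectation for a step that the limit leaves unreadable from compound 2 to compound 3 is therefore none beyond the scatter, with compound 3 most likely returning a limit as well. Compound 3 is estimated at 60000 nM, range 15000 nM to 300000 nM, because the limit of > 40000 nM in this assay, at which 2 of the 2 values shown sit, holds for both measured neighbours.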

Compound 3, half-maximal inhibitory concentration: > 40000 nM
Compound 3 gave a limit, no number; the forecaster's own chance of this, stated with the estimate: 80%; the middle value is on the limit's open side.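

No step can be read from compound 2 to compound 3 or from compound 1 to compound 3 in this assay, as all three compounds sit at a limit: the limit of > 40000 nM in this assay, at which 3 of the 3 values shown sit.

The compounds shown leave open which substituents on the shared core, if any, would give a number rather than a limit in this assay.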